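The source may report more compounds than this note shows. Statements on the series, on what has been measured and on what is new or still open speak of the compounds shown alone.

Measured in an in vitro ADME assay on microsomes (Rattus norvegicus) for metabolic stability; a lower number here means that the compound disappears faster, a higher number that the compound lasts longer:
- compound 1 `CCC(CC)Nc1nc(OC)c(-c2ccc(Cl)cc2Cl)nc1C`: 0.283 h
- compound 2 `CCc1nc(-c2ccc(OC(F)F)cc2Cl)c(OC)nc1NC(CC)CC`: 0.283 h
- compound 3 `CCC(CC)Nc1nc(OC)c(-c2ccc(Cl)cc2Cl)nc1OC`: 0.0417 h

Compound 3 has the lowest number of the three. Compound 4 `CCc1nc(-c2ccc(Cl)cc2Cl)c(OC)nc1NC(CC)CC` differs from it by ethyl in place of methoxy on an aromatic carbon. Within the data shown here, one measured step bears on this: a 6.8-fold lower number from compound 1 to compound 3 (0.83 log units; beyond the scatter), a modest step that brought methoxy in place of methyl on an aromatic carbon. Removing methoxy should therefore reverse much of that drop, and compound 2, which also carries ethyl, gives 0.283 h. The expected change is a rise beyond the scatter, estimated as a 6.0-fold higher number from compound 3 to compound 4 (0.78 log units; beyond the scatter). For compound 4 the estimated half-life is 0.25 h, with an expected range of 0.1 h to 0.5 h.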

Compound 4, half-life: 0.183 h
Estimate against measurement, compound 4: 1.4-fold (0.14 log units) above; low and high end bracket the measured number.
By their numbers in this assay, from the lowest: compound 3; then compounds 4, 1 and 2 (each within the scatter of the next).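

In this assay ethyl in place of methoxy at this position gives a clear rise (a 4.4-fold higher number from compound 3 to compound 4 (0.64 log units; beyond the scatter)), so both methyl and ethyl here stand clear of methoxy. The two alkyl groups cannot be told apart (a 1.5-fold lower number from compound 1 to compound 4 (0.19 log units; within the scatter)), and neither can chloro and difluoromethoxy elsewhere in the molecule when ethyl is held at this position (a 1.5-fold lower number from compound 2 to compound 4 (0.19 log units; within the scatter)). No supporting evidence explains why methoxy stands apart. On these data alone, whether a propyl chain, a bare hydrogen or an amine here would stay with the alkyl groups or drop towards methoxy remains open.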